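This account rests on a few compounds, and the source may have more. Where it says the series, first, only, none or still open, it means among the compounds named here.

Measured so far:
compound 1, `CCCCCCCCNC(=S)N1[C@H](CO)[C@@H](O)[C@H](O)[C@H]1CO`: 414000 nM in an assay for inhibition of beta-galactosidase (Bos taurus), read by spectrophotometry; a lower number here means a stronger inhibitor, a higher number a weaker inhibitor
compound 2, `CCCCCC/N=C1/SC[C@H]2[C@H](O)[C@@H](O)[C@H](CO)N12`: 599000 nM in this assay

Compound 2 has the higher of the two numbers in this assay, yet its number and that of compound 1 lie within the usual scatter of each other, so the two cannot be told apart. Compound 3, `CCCCCCCCCC/N=C1/SC[C@H]2[C@H](O)[C@@H](O)[C@H](CO)N12`, differs from compound 2 by butyl in place of hydrogen on a saturated chain carbon, six bonds along the chain from a double-bonded nitrogen. Going by the values given here, no measured pair shows what such a chain extension does here, so the step is expected to be small, a modest move toward a lower number at most, with no change beyond the scatter also possible. For compound 3 the estimate in this assay is 300000 nM, between 60000 nM and 1500000 nM, which means an expected step of a 2.0-fold lower number from compound 2 to compound 3 (0.30 log units; within the scatter).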

Compound 3, half-maximal inhibitory concentration: 36000 nM
The estimate for compound 3 lay 8.3-fold (0.92 log units) above the measured number, outside the stated range (below it).
By their numbers in this assay, from the lowest: compound 3; then compounds 1 and 2 (each within the scatter of the next).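

In this assay butyl in place of hydrogen on a saturated chain carbon, six bonds along the chain from a double-bonded nitrogen, gives a 17-fold lower number from compound 2 to compound 3 (1.22 log units; beyond the scatter) and lies beyond the scatter. This first measured pair therefore shows that this chain position is not silent and that adding to the chain here can matter a great deal. Nothing available explains why the step is so large.

As far as these compounds go, whether a longer chain such as dodecyl would lower the number further remains open. So does whether a phenyl or an amine at the chain end would preserve the step.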